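Carboxy to Tetrazole: Expected Solubility of Compound 4

The compounds below may be only part of what the source reports. "The series", "measured", "known", "first", "only" and "open" are said of these compounds alone.

Measured compounds and their values:
Compound 1, `FC(F)(F)c1ccc(Nc2cc3[nH]c(-c4cccc(C(F)(F)F)c4)nc3cn2)nc1`: >= 50000 nM
Compound 2, `O=C(O)c1ccc(Nc2cc3[nH]c(-c4cccc(C(F)(F)F)c4)nc3cn2)nc1`: 6000 nM
Compound 3, `O=C(O)c1ccnc(Nc2cc3[nH]c(-c4cccc(C(F)(F)F)c4)nc3cn2)c1`: 60000 nM

Of the compounds shown here, three on a shared core have been tested in a physicochemical assay for solubility, using the shake flask method, in simulated intestinal fluid, measured as kinetic solubility, with a stated time of 20 h, at pH 6.5; a higher number here means a more soluble compound, a lower number a less soluble compound. The value for compound 1 is a limit of this assay, not a number. Of the two numbers, compound 2 stands lowest: a 10-fold higher number from compound 2 to compound 3 (1.00 log units; beyond the scatter).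

Compound 4, `FC(F)(F)c1cccc(-c2nc3cnc(Nc4ccc(-c5nnn[nH]5)cn4)cc3[nH]2)c1`, is not yet measured. It differs from compound 2 in one place: 1H-tetrazol-5-yl in place of carboxy on an aromatic carbon. For the measured compounds named here, two measured steps bear on it. The step of an at least 8.3-fold lower number from compound 1 to compound 2 (0.92 log units; beyond the scatter) shows that carboxy at this position goes with a much lower number than trifluoromethyl. The step of a 10-fold higher number from compound 2 to compound 3 (1.00 log units; beyond the scatter) shows that the position of carboxy on its ring matters by a modest amount. Going by the values given here, neither step tests 1H-tetrazol-5-yl, so the change has no direct precedent here.

The step of no change at the digits printed from compound 2 to compound 4 (within the scatter) is expected to stay within the usual scatter, since the replacing group keeps a hydrogen-bond donor at the same position. Compound 4 is therefore estimated at 6000 nM, with a range from 2000 nM to 20000 nM.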

Compound 4, solubility: < 5000 nM
Compound 4: no number, only a limit; the forecaster's own chance of this, stated with the estimate: 5%; middle value at least 1.2-fold (0.07 log units) away from the limit.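

In this assay, compound 4 gives a limit and not a number: the limit of < 5000 nM in this assay, at which 1 of the 4 values shown sits. On this aromatic carbon, 1H-tetrazol-5-yl in place of carboxy gives an at least 1.2-fold lower number from compound 2 to compound 4 (0.07 log units; that floor lies within the scatter), so the change does not raise the number, while its true size could be small or large. Against trifluoromethyl the picture is clearer, with an at least 10-fold lower number from compound 1 to compound 4 (1.00 log units; beyond the scatter), so 1H-tetrazol-5-yl joins carboxy in going with a much lower number than trifluoromethyl at this place.

Carboxy shows that its place on the ring can matter, with a 10-fold higher number from compound 2 to compound 3 (1.00 log units; beyond the scatter), but whether 1H-tetrazol-5-yl would respond to such a move in the same way remains open. Going by these compounds, how an amide or a sulfonic acid on this aromatic carbon would read is also open.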